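Chain amine variation in a T-type calcium channel series

The compounds below may be only part of what the source reports. "The series", "measured", "known", "first", "only" and "open" are said of these compounds alone.

compound 1 `CN(C)CCCCCSC1=Nc2ccccc2C(CC(=O)NCc2ccccc2)N1c1ccc(-c2ccc(F)cc2)cc1`: 250 nM
compound 2 `CN(C)CCCCCSC1=Nc2ccccc2C(CC(=O)NCc2ccccc2)N1c1ccc(-c2ccccc2)cc1`: 7770 nM

Among the measured compounds shown here, in an assay on cells for inhibition of Voltage-dependent T-type calcium channel subunit alpha-1G (Homo sapiens), read by patch clamp (on this read-out lower numbers stand for stronger inhibition and higher numbers for weaker inhibition), compound 1 gives 250 nM, the lower of the two numbers so far, and the only measured step is a 31-fold higher number from compound 1 to compound 2 (1.49 log units; beyond the scatter). Compound 3 `O=C(CC1c2ccccc2N=C(SCCCCCN2CCCC2)N1c1ccc(-c2ccc(F)cc2)cc1)NCc1ccccc1` has not yet been measured in this assay. It differs from compound 1 by pyrrolidin-1-yl in place of dimethylamino on a saturated chain carbon, five bonds along the chain from a sulfur. For the measured compounds named here, the one measured step concerns a substituent on an aromatic carbon and touches nothing on the chain or its terminal amine, so no measured step bears on the change from compound 1 to compound 3, and the series offers no direction for it. In the absence of any pointer, the step of no change at the digits printed from compound 1 to compound 3 (within the scatter) is expected to stay within the scatter. Compound 3 is therefore estimated at 250 nM in this assay, with a range from 100 nM to 650 nM.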

Compound 3, half-maximal inhibitory concentration: 2180 nM
The estimate for compound 3 lay 8.7-fold (0.94 log units) below the measured number; the whole stated range lies below it.
By their numbers in this assay, from the lowest: compound 1; then compound 3; then compound 2.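

In this assay, the end of the chain proves sensitive: pyrrolidin-1-yl in place of dimethylamino on a saturated chain carbon, five bonds along the chain from a sulfur, gives an 8.7-fold higher number from compound 1 to compound 3 (0.94 log units; beyond the scatter). Among the compounds shown here, this is the first measured change at this position, and it shows that the read-out responds to the terminal amine as well as to the fluoro on the aromatic carbon. No measurement at hand explains the step.

From the compounds shown here alone, with one replacement at this position, it remains open whether the higher number goes with the ring, the added carbons or pyrrolidin-1-yl alone; diethylamino, piperidin-1-yl and morpholin-4-yl at the chain end would help separate these. Also open, going by these compounds, is whether a shorter or longer chain would change the size of the step.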